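The source may report more compounds than this note shows. Statements on the series, on what has been measured and on what is new or still open speak of the compounds shown alone.

Measured so far in a functional assay on HCT-15 cells (Homo sapiens) for cytotoxicity, read by ELISA, with a stated time of 4 days; on this read-out lower numbers stand for stronger inhibition and higher numbers for weaker inhibition:

- Compound 1 `Cc1ccsc1-c1cc(-c2ccco2)cc(-c2ccc(Cl)cc2)n1`: 710 nM
- Compound 2 `Clc1ccc(-c2cc(-c3ccoc3)cc(-c3ccco3)n2)s1`: 1280 nM
- Compound 3 `Cc1ccc(-c2cc(-c3ccoc3)cc(-c3ccc(Cl)s3)n2)cc1`: 1170 nM

These three numbers all lie within the usual scatter of one another, so compound 3, at 1170 nM, stands level with compound 1 and compound 2, and no order can be read among them.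

The next compound is compound 4 `Clc1ccc(-c2cc(-c3ccoc3)cc(-c3cccnc3)n2)s1`. Compared with compound 3, it carries pyridin-3-yl in place of 4-methylphenyl on an aromatic carbon next to the ring nitrogen (pyridin-3-yl in place of 4-methylphenyl on an aromatic carbon).

Within the data shown here, one measured step bears on this change, as it swaps the group on that same carbon: a 1.1-fold lower number from compound 2 to compound 3 (0.04 log units; within the scatter). There, 4-methylphenyl replaced furan-2-yl and the number did not move beyond the scatter. That is only a single step, and pyridin-3-yl has not been measured in any of these compounds, so the range stays wide. In this assay, no step beyond the scatter is expected. The expected step is a 1.2-fold higher number from compound 3 to compound 4 (0.08 log units; within the scatter). Compound 4 is estimated at 1400 nM, with an expected range of 600 nM to 3500 nM.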

Compound 4, half-maximal inhibitory concentration: 720 nM
Compound 4: middle estimate off by 1.9-fold (0.29 log units), on the high side; measured number inside the range.
By their numbers in this assay, from the lowest: compounds 1, 4, 3 and 2 (each within the scatter of the next).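

In this assay, pyridin-3-yl on this aromatic carbon next to the ring nitrogen gives a 1.6-fold lower number from compound 3 to compound 4 (0.21 log units; within the scatter) and also a 1.8-fold lower number from compound 2 to compound 4 (0.25 log units; within the scatter) when set against furan-2-yl. With the 5-chlorothiophen-2-yl and furan-3-yl groups unchanged, this carbon has now carried three different aromatic rings without any step going beyond the scatter, even though pyridin-3-yl counts one hydrogen-bond acceptor where 4-methylphenyl counts none. Nothing in the data available here offers an explanation for these numbers.

Still open, from the compounds shown here alone, is whether a group of another kind on this carbon, such as an amine, a carboxylic acid or a longer chain, would produce a step beyond the scatter. The compounds shown also leave open how far pyridin-2-yl or pyridin-4-yl would differ from pyridin-3-yl here.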